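Pyridin-4-yl for pyrimidin-5-yl on the shared core

The compounds below may be only part of what the source reports. "The series", "measured", "known", "first", "only" and "open" are said of these compounds alone.

Working notes on a functional assay on VCaP cells (Homo sapiens) for antiproliferative activity, read by CCK-8 assay, with a stated time of 6 days; a higher number here means a weaker inhibitor, a lower number a stronger inhibitor. Compound 1 (`CCN(c1ccc(C#N)c(Cl)c1)c1cc(-c2ccc(F)nc2)ccc1C`) gives > 30000 nM, which is a limit of the assay and not a number. Compound 2 (`N#Cc1ccc(N2CCc3cc(-c4cnc5ccccc5c4)ccc3C2)cc1C(F)(F)F`) shares its core with compound 3 and compound 4. Compound 2 gives > 30000 nM, also a limit of the assay. Compound 3 (`N#Cc1ccc(N2CCc3cc(-c4cncnc4)ccc3C2)cc1C(F)(F)F`) has no single number, and its entry reads "not determined" (no result reported). Going by the values given here, the series therefore offers no measured value for compound 3 to start from, and the only evidence is the limit of > 30000 nM in this assay, at which 2 of the 3 values shown sit.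

The compound to be measured next is compound 4 (`N#Cc1ccc(N2CCc3cc(-c4ccncc4)ccc3C2)cc1C(F)(F)F`). The step pyridin-4-yl in place of pyrimidin-5-yl on an aromatic carbon puts pyridin-4-yl in place of pyrimidin-5-yl on an aromatic carbon of the shared core.

Among the compounds with values here, no measured step exists to scale this change, so no shift beyond the usual scatter is expected in this assay, in either direction. Compound 4 is expected to read close to the limit, with an estimated value of 20000 nM and an expected range of 4000 nM to 30000 nM.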

Compound 4, half-maximal inhibitory concentration: 3500 nM
Beside the measured number, compound 4's estimate is 5.7-fold (0.76 log units) above it; the whole stated range lies above it.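

Compound 4 is the only compound shown in this assay that gives a number and not a limit, so a group on this aromatic carbon of the shared core can bring the read-out into the measurable range. On this carbon, pyridin-4-yl in place of quinolin-3-yl gives an at least 8.5-fold lower number from compound 2 to compound 4 (0.93 log units; beyond the scatter), and the size is a lower bound, the value of compound 2 being a limit. The step from compound 3 to compound 4 cannot be read, so the effect of pyridin-4-yl in place of pyrimidin-5-yl remains unsized.

Open, going by these compounds, is whether an amine or a carboxylic acid on the pyridin-4-yl ring, or a plain phenyl ring in its place, would move the number. A trend cannot be drawn from a single number, and the rest of the series gives little to set against it: the limit of > 30000 nM in this assay, at which 2 of the 4 values shown sit.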